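A few compounds are considered here, and "the series" means these few. Any claim that something is new, unique, unknown or untested is made for them only; others in the source may bear on it.

Measured in an assay on HeLa cells with Bile acid receptor (Homo sapiens) as the target, read by a luciferase reporter, with a stated time of 24 h; on this read-out higher numbers stand for an effect only at larger amounts of compound and lower numbers for an effect already at smaller amounts:

Compound 1 `O=C(O)c1ccc(CNC(=O)c2cccc(-c3ccccc3)c2)cc1` gives 670 nM.
Compound 2 `CN(C)C(=O)c1ccc(CNC(=O)c2ccc(C(C)(C)C)cc2)cc1` gives 170 nM.
Compound 3 `CC(C)(C)c1ccc(C(=O)NCc2ccc(N)cc2Cl)cc1` gives 46 nM.

Among these three numbers, compound 2 stands second highest. Its nearest neighbour is compound 3, whose number is lower by a margin beyond the usual scatter; furthest from it is compound 1, whose number is higher, again beyond the scatter. Compound 2 is thus neither the weakest nor the strongest of the three.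

The compound still to be measured is compound 4 `CC(C)(C)c1ccc(C(=O)NCc2ccc(OCC(=O)O)cc2)cc1`. It differs from compound 2 in a single place: carboxymethoxy in place of dimethylcarbamoyl on an aromatic carbon. Going by the values given here, no pair of measured compounds differs in exactly this way, so the size of the step has to be guessed from the wider picture. Compound 1, which also carries an acid group, gives the highest number of the three, but it differs from compound 2 in a second place as well, so it is only a loose hint. The step from compound 2 to compound 4 is expected to be small, probably toward a higher number, and possibly within the scatter a 1.5-fold higher number from compound 2 to compound 4 (0.17 log units; within the scatter). Compound 4 is therefore expected to give about 250 nM in this assay, with a plausible range from 80 nM to 800 nM.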

Compound 4, half-maximal effective concentration: 730 nM
Beside the measured number, compound 4's estimate is 2.9-fold (0.47 log units) below it, and the stated range covers the measured number.
By their numbers in this assay, from the lowest: compound 3; then compound 2; then compounds 1 and 4 (each within the scatter of the next).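

In this assay, carboxymethoxy in place of dimethylcarbamoyl on an aromatic carbon, para to a large group, brings a 4.3-fold higher number from compound 2 to compound 4 (0.63 log units; beyond the scatter), so this position is sensitive to which group it carries. The two groups have the same number of heavy atoms and neither contains a ring, yet they differ in their atoms and in their hydrogen-bond donors and acceptors, so matching the heavy-atom count does not preserve the number. Nothing available explains why the number rises with this change.

This single step cannot separate the contribution of the ether oxygen from that of the end carboxyl group. It also leaves open how a methoxy, a hydroxyl or a longer carboxypropoxy chain at the same position would compare with carboxymethoxy.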